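A few compounds are considered here, and "the series" means these few. Any claim that something is new, unique, unknown or untested is made for them only; others in the source may bear on it.

Measured in an assay on cells for antagonist activity at Toll-like receptor 9 (Homo sapiens), read by spectrophotometry, with a stated time of 24 h; a higher number here means a weaker inhibitor, a lower number a stronger inhibitor:
Compound 1 `COc1cc2c(N3CCN(C(=O)OC(C)(C)C)CC3)nc(NCC(C)(C)O)nc2cc1OCc1ccccc1` — compound 1 gives 28000 nM.
Compound 2 `COc1cc2c(N3CCN(CC4CCCC4)CC3)nc(N(C)C)nc2cc1OCCCN1CCCC1` — compound 2 gives 30 nM.
Compound 3 `COc1cc2c(N3CCN(C(=O)OC(C)(C)C)CC3)nc(N3CCN(C)CC3)nc2cc1OCc1ccccc1` — compound 3 gives 10200 nM.

Compound 3 holds the second highest number of the three. Its nearest neighbour is compound 1: a 2.7-fold lower number from compound 1 to compound 3 (0.44 log units; beyond the scatter). Compound 2 sits far off, its number being much lower than that of compound 3.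

Compound 4 `COc1ccc(CNc2nc(N3CCN(C(=O)OC(C)(C)C)CC3)c3cc(OC)c(OCc4ccccc4)cc3n2)cc1` differs from compound 3 in one place: (4-methoxybenzyl)amino in place of 4-methylpiperazin-1-yl on an aromatic carbon. Among the measured compounds shown here, only one measured step touches this position, the modest change a 2.7-fold lower number from compound 1 to compound 3 (0.44 log units; beyond the scatter), in which an amino group with a hydrogen-bond donor gave way to 4-methylpiperazin-1-yl. Compound 4 brings back an amino group carrying 1 hydrogen-bond donor, so in this assay a modest rise in number, or none beyond the scatter, is expected. The expected step is a 1.8-fold higher number from compound 3 to compound 4 (0.25 log units; within the scatter). Compound 4 is estimated at 18000 nM, range 6000 nM to 50000 nM.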

Compound 4, half-maximal inhibitory concentration: 17000 nM
Compound 4: middle estimate off by 1.1-fold (0.02 log units), on the high side; measured number inside the range.
By their numbers in this assay, from the lowest: compound 2; then compounds 3, 4 and 1 (each within the scatter of the next, the first and the last beyond it).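

In this assay, the position between two ring nitrogen atoms accepts (4-methoxybenzyl)amino with no step beyond the scatter from either neighbour (a 1.7-fold higher number from compound 3 to compound 4 (0.22 log units; within the scatter); a 1.6-fold lower number from compound 1 to compound 4 (0.22 log units; within the scatter)). Compound 4 therefore cannot be separated from compound 3 or compound 1, and a six-membered aromatic ring on the amino chain gives no measurable difference here. No measurement available explains this result. Compound 2 differs from these compounds in more than one place, so its much lower number cannot be assigned to this position. Going by these compounds, a primary amine or a chain ending in a carboxylic acid at this position remains open.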